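The source may report more compounds than this note shows. Statements on the series, on what has been measured and on what is new or still open speak of the compounds shown alone.

Compound 1 `CC(C)n1ncc2c(C(=O)Nc3c(F)cccc3F)cc(-c3cccs3)nc21` was examined in an ADME assay on LLC-MK2 cells (Macaca mulatta) for cytotoxicity, read by spectrophotometry and crystal violet staining, with a stated time of 4 days; on this read-out lower numbers stand for higher toxicity in this test and higher numbers for lower toxicity in this test. In this assay compound 1 gives > 200000 nM, which is a limit of the assay. Two related compounds were measured alongside it. Compound 2 `CC(C)n1ncc2c(C(=O)N3CCc4cc(F)ccc43)cc(-c3cccs3)nc21` gives > 200000 nM in this assay, again a limit. Compound 3 `CC(C)n1ncc2c(C(=O)Nc3ccncn3)cc(-c3ccsc3)nc21` gives > 200000 nM in this assay, also a limit. All three measured values therefore stand at the limit of > 200000 nM in this assay, at which 3 of the 3 values shown sit, so the measurements made so far do not separate any of these compounds from the others in this assay.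

Compound 4 `CC(C)n1ncc2c(C(=O)Nc3cc(F)ccc3F)cc(-c3cccs3)nc21` has not yet been measured. It differs from compound 1 in one place: 2,5-difluorophenyl in place of 2,6-difluorophenyl on an amide-type nitrogen. For the measured compounds named here, no measured pair of compounds differs in a single place, so no measured step is available to guide the expectation. The estimated step that the limit leaves unreadable from compound 1 to compound 4 is expected to be none beyond the scatter, as all three measured values sit at the limit of > 200000 nM in this assay, at which 3 of the 3 values shown sit. Compound 4 is accordingly expected to give about 250000 nM in this assay, within a range from 150000 nM to 500000 nM, and most probably to be reported once more as a limit.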

Compound 4, half-maximal cytotoxic concentration: 100000 nM
Compound 4: the middle estimate sits 2.5-fold (0.40 log units) above what was measured, and the stated range ends above it.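

In this assay, for the compounds shown here, compound 4 gives 100000 nM, the only value shown here that is a number and not a limit, so this set of compounds can give a measurable reading in this test. Placing 2,5-difluorophenyl instead of 2,6-difluorophenyl on the amide-type nitrogen keeps the same atoms, joined differently, and the change comes out as an at least 2.0-fold lower number from compound 1 to compound 4 (0.30 log units; that floor lies within the scatter). This is only a floor, and the full size of the step cannot be read, because compound 1 stands at a limit: the limit of > 200000 nM in this assay, at which 3 of the 4 values shown sit.

The compounds shown do not settle whether this change reaches beyond the usual scatter. They also leave open what an unsubstituted phenyl, or a phenyl carrying chlorine or a methoxy group, would give on the same nitrogen.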